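A Longer Chain on the Shared Core: Expected Antiproliferative Potency

This account rests on a few compounds, and the source may have more. Where it says the series, first, only, none or still open, it means among the compounds named here.

Compound 1 `CCCCCCCn1cc(COC[C@@H]2OC[C@H](N)[C@@H]2O)nn1` — > 128000 nM
Compound 2 `CCCCCCCn1cc(COC[C@@H]2OC[C@H](N)[C@H]2O)nn1` — > 128000 nM

Compound 1 `CCCCCCCn1cc(COC[C@@H]2OC[C@H](N)[C@@H]2O)nn1` was tested in a functional assay on MCF7 cells (Homo sapiens) for antiproliferative activity, read by MTT assay, with a stated time of 48 h (on this read-out lower numbers stand for stronger inhibition and higher numbers for weaker inhibition), where compound 1 gives > 128000 nM, which is a limit of the assay rather than a number. Compound 2 `CCCCCCCn1cc(COC[C@@H]2OC[C@H](N)[C@H]2O)nn1` in this assay gives > 128000 nM, again a limit of the assay. Compound 2 thus stands at the limit, with no measured number of its own. Among the compounds with values here, because of the limit of > 128000 nM in this assay, at which 2 of the 2 values shown sit, and (the fact that compounds 1 and 2 differ only in the configuration as drawn), the only measured step is a step that the two limits leave unreadable from compound 1 to compound 2. Compound 3 `CCCCCCCCCCCCCCCCCCn1cc(COC[C@@H]2OC[C@H](N)[C@H]2O)nn1` differs from compound 2 by undecyl in place of hydrogen on a saturated chain carbon, seven bonds along the chain from an aromatic nitrogen. Within the data shown here, no measured step touches the chain, so nothing measured bears on this change, and the single measured step gives no readable size. The expectation rests only on the limit at which compound 2 sits. Compound 3 is expected to give 100000 nM in this assay, within 20000 nM to 128000 nM. The estimated step is an at least 1.2-fold lower number from compound 2 to compound 3 (0.10 log units; that floor lies within the scatter), most likely again reported as a limit.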

Compound 3, half-maximal inhibitory concentration: 1930 nM
Beside the measured number, compound 3's estimate is 52-fold (1.71 log units) above it; the whole stated range lies above it.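

In this assay, undecyl in place of hydrogen on a saturated chain carbon, seven bonds along the chain from an aromatic nitrogen, gives the first readable step among these compounds: an at least 66-fold lower number from compound 2 to compound 3 (1.82 log units; beyond the scatter). Within the data shown here, the heptyl-length chain of the earlier compounds gave no number at all, so this result shows that the chain position is one where a change can move the read-out by a large amount. The size is a floor rather than an exact figure, because compound 2 has no number of its own: the limit of > 128000 nM in this assay, at which 2 of the 3 values shown sit.

From the compounds shown here alone, whether a chain of intermediate length or a longer chain still would give a lower number stays open, as does the effect of an amine or a carboxylic acid at the chain end. Going by these compounds, the step between compound 1 and compound 2 cannot be read, so whether the drawn configuration matters on the longer chain also remains open.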